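The source may hold more compounds than are shown below. What is called first, only, known or untested is meant among the compounds shown, and "the series" means these compounds.

Measured in a functional assay on Hep 3B2 cells (Homo sapiens) for antiproliferative activity, read by MTT assay, with a stated time of 24 h, tested at 0.01 ug/mL; a higher number here means a stronger effect of the compound at the concentration tested, a lower number a weaker effect:
compound 1 `CCc1ccc2nc(C(=O)Nc3c(F)cc(-c4cccc(F)c4)cc3F)c(C)c(O)c2c1` gives 0.74%
compound 2 `Cc1c(C(=O)Nc2c(F)cc(-c3cccc(F)c3)cc2F)nc2ccc(C(F)(F)F)cc2c1O` gives -0.33%
compound 3 `COc1ccc2nc(C(=O)Nc3ccc(-c4ccccc4)cc3)c(C)c(O)c2c1` gives 0.35%

All three numbers sit close together. Compound 3 stands in the middle of the three on the numbers shown, with compound 1 nearest and compound 2 furthest, and both gaps lie within the scatter, so no order among the three can be read. Among the compounds with values here, the only step between measured compounds that differ in one place, a number 1.1 percentage points lower from compound 1 to compound 2 (within the scatter), also lies within the scatter.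

Compound 4 `Cc1c(C(=O)Nc2ccc(-c3ccccc3)cc2)nc2ccccc2c1O` differs from compound 3 by hydrogen in place of methoxy on an aromatic carbon. Within the data shown here, no measured step touches this group, and the one step that is known concerns a different group and did not move the read-out beyond the scatter. Among the measured compounds shown here, nothing measured so far suggests that any single change shifts this assay beyond the scatter. The expected step is therefore a number 0.1 percentage points lower from compound 3 to compound 4 (within the scatter), that is, none beyond the scatter. Compound 4 is estimated to give 0.3%, with a range from -2% to 2.6%.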

Compound 4, a percentage reported as inhibition, at one concentration (the size of the read-out at that concentration, not a potency): 0.23%
For compound 4 the middle estimate is 0.1 percentage points above the measured one; the measured number falls inside the stated range.
By their numbers in this assay, from the lowest: compounds 2, 4, 3 and 1 (each within the scatter of the next).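

With hydrogen in place of methoxy on this aromatic carbon of the six-membered aromatic ring of carbon only, this assay gives a number 0.1 percentage points lower from compound 3 to compound 4 (within the scatter). This is the first measured step that removes a substituent from this carbon rather than exchanging one for another, and the read-out does not separate methoxy from hydrogen among the compounds with the unsubstituted biphenyl-type amide part shown here. No measured data bear on why this step is so small.

Going by these compounds, whether an amine, a carboxylic acid or a longer alkoxy chain on this carbon would give a step beyond the scatter remains open. On these data alone, since compound 3 and compound 4 each differ from compound 1 and compound 2 in more than one place, the effect of the fluorines on the amide part also remains open.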